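A few compounds are considered here, and "the series" means these few. Any claim that something is new, unique, unknown or untested is made for them only; others in the source may bear on it.

Measured so far in an ADME assay on LLC-MK2 cells (Macaca mulatta) for cytotoxicity, read by spectrophotometry and crystal violet staining, with a stated time of 4 days; on this read-out higher numbers stand for lower toxicity in this test and lower numbers for higher toxicity in this test:

Compound 1 `CC(C)n1ncc2c(C(=O)Nc3ccccn3)cc(C3CC3)nc21` gives 25000 nM.
Compound 3 `CC(C)n1ncc2c(C(=O)Nc3ccc(F)cc3)cc(C3CC3)nc21` gives 12500 nM.
Compound 2 `CC(C)n1ccc2c(C(=O)Nc3ccccn3)cc(-c3cccs3)nc21` gives only a limit of the assay, > 200000 nM, one of the values at the limit of > 200000 nM in this assay, at which 1 of the 3 values shown sits.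

Compound 1 and compound 3 share a core and differ by 4-fluorophenyl in place of pyridin-2-yl on an amide-type nitrogen. In this assay this step is a 2.0-fold lower number from compound 1 to compound 3 (0.30 log units; within the scatter), so the two values cannot be ordered against each other.

Compound 2 carries a different core; the difference between the core of compound 1 and the core of compound 2 is not broken down here.

Going by the values given here, compound 4 `CC(C)n1ccc2c(C(=O)Nc3ccc(F)cc3)cc(-c3cccs3)nc21`, not yet measured in this assay, stands to compound 2 as compound 3 stands to compound 1: the difference is 4-fluorophenyl in place of pyridin-2-yl on an amide-type nitrogen, at the same place in both pairs, and so it is the same change as the one between compound 1 and compound 3.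

For compound 4 the step from compound 2 is expected to be about a number no higher from compound 2 to compound 4 (the limit leaves the size open), beside the earlier step of a 2.0-fold lower number from compound 1 to compound 3 (0.30 log units; within the scatter), which rests on that earlier step being within the scatter. Since compound 2 sits at a limit of the assay, the reading for compound 4 is also expected to sit at or near that limit. Compound 4 is therefore estimated at 200000 nM, with a range from 80000 nM to 400000 nM.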

Compound 4, half-maximal cytotoxic concentration: > 200000 nM
Compound 4 ended at the assay's limit; the forecaster's own chance of this, stated with the estimate: 65%; the middle value lies on the limit itself.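

In this assay compound 2 gives > 200000 nM as a limit of the assay. Compound 4 gives > 200000 nM as a limit too. No step can be read from compound 2 to compound 4 for 4-fluorophenyl in place of pyridin-2-yl on an amide-type nitrogen: the limit of > 200000 nM in this assay, at which 2 of the 4 values shown sit. The compounds shown leave open how far past that limit either compound lies, and so whether this change has any size on the core of compound 2.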